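From compound 3 to compound 4: a longer amino chain

The compounds below may be only part of what the source reports. "The series", "measured", "known", "first", "only" and "open" are said of these compounds alone.

- compound 1 `O=C(NCc1ccc(F)cc1)c1nc(Br)c2cccnc2c1NCc1ccc(F)cc1` gives > 20000 nM (a limit of the assay, not a number)
- compound 2 `N[C@H]1CC[C@H](Nc2c(C(=O)NCc3ccc(F)cc3)nc(Br)c3cccnc23)CC1` gives 6000 nM
- compound 3 `CNCCCNc1c(C(=O)NCc2ccc(F)cc2)nc(Br)c2cccnc12` gives 11000 nM

All three values come from a functional assay on MDA-MB-435 cells (Homo sapiens) for cytotoxicity, read by MTT assay, with a stated time of 72 h (on this read-out higher numbers stand for weaker inhibition and lower numbers for stronger inhibition), and the compounds share one core. Going by the values given here, only two of the values are true numbers, and they sit within the scatter of each other, with a 1.8-fold higher number from compound 2 to compound 3 (0.26 log units; within the scatter) as the whole gap. Compound 3 therefore stands level with compound 2 on these data.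

The next compound is compound 4 `NCCCCCCNc1c(C(=O)NCc2ccc(F)cc2)nc(Br)c2cccnc12` in which 3-aminopropyl takes the place of methylamino on a saturated chain carbon, three bonds along the chain from a nitrogen on an aromatic ring. The counted change is 3-aminopropyl in place of methylamino on a saturated chain carbon, three bonds along the chain from a nitrogen on an aromatic ring and the whole group thus goes from 3-(methylamino)propyl to 6-aminohexyl.

The nearest guide is the swap of 4-aminocyclohexyl for 3-(methylamino)propyl, a change of the same group that stayed small. The steps that start from the limit, an at least 3.3-fold lower number from compound 1 to compound 2 (0.52 log units; beyond the scatter) and an at least 1.8-fold lower number from compound 1 to compound 3 (0.25 log units; that floor lies within the scatter), replace a group without any amino function and say less here. Compound 4 keeps an amino group on a saturated chain, so no large move is foreseen.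

The estimate amounts to a 1.4-fold lower number from compound 3 to compound 4 (0.14 log units; within the scatter) and thus no expected step beyond the scatter. For compound 4 the expected value is 8000 nM with an estimated range from 2500 nM to 20000 nM in this assay before any measurement.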

Compound 4, half-maximal inhibitory concentration: 6000 nM
The estimate for compound 4 lay 1.3-fold (0.12 log units) above the measured number; low and high end bracket the measured number.
By their numbers in this assay, from the lowest: compounds 2, 4 and 3 (each within the scatter of the next). At a limit, above all of these: compound 1.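

In this assay, the longer chain of compound 4 gives a 1.8-fold lower number from compound 3 to compound 4 (0.26 log units; within the scatter), and replacing the ring of 4-aminocyclohexyl with the open chain of 6-aminohexyl gives no change at the digits printed from compound 2 to compound 4 (within the scatter), so at this position neither chain length nor the swap of a ring for an open chain produces a step that can be told apart from the scatter. Like compound 2, compound 4 separates from compound 1 that carries no amino group on this side, with an at least 3.3-fold lower number from compound 1 to compound 4 (0.52 log units; beyond the scatter), whereas the corresponding floor for compound 3 stays within the scatter. That step gives only a floor, since compound 1 stands at a limit and not at a true number: the limit of > 20000 nM in this assay, at which 1 of the 4 values shown sits.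

As far as these compounds go, what the amino group itself contributes remains open, and a hydroxyl at the end of the same chain, in place of the amine, would separate its role from that of the chain. It is also unknown whether a still longer chain ending in an amine, or a dimethylamino group at the chain end, would move the number beyond the scatter.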